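Formyl to Acetyl on the Shared Vinyl Arm

The source may hold more compounds than are shown below. What is called first, only, known or untested is meant among the compounds shown, and "the series" means these compounds.

Measured so far:
compound 1 `Cc1cn(/C=C/C=O)c(=O)[nH]c1=O` — 23000 nM in a functional assay on HeLa cells (Homo sapiens) for inhibition; on this read-out higher numbers stand for weaker inhibition and lower numbers for stronger inhibition
compound 2 `CC(=O)/C=C/n1cc(C)c(=O)[nH]c1=O` — > 100000 nM in this assay, a limit of the assay
compound 3 `O=C/C=C/n1c(=O)ccn([C@H]2C[C@H](O)[C@@H](CO)O2)c1=O` — 800 nM in this assay

Compound 3 stands lowest of the two numbers, with compound 1 the nearest. How the core of compound 1 and the core of compound 3 differ is not broken down here. Between compound 1 and compound 2 the only change is methyl in place of hydrogen on a carbonyl carbon, and it made an at least 4.3-fold higher number from compound 1 to compound 2 (0.63 log units; beyond the scatter); the number for compound 2 is a limit only (the limit of > 100000 nM in this assay, at which 1 of the 3 values shown sits).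

Compound 4 `CC(=O)/C=C/n1c(=O)ccn([C@H]2C[C@H](O)[C@@H](CO)O2)c1=O` is not yet measured. It differs from compound 3 by methyl in place of hydrogen on a carbonyl carbon, the same change as that from compound 1 to compound 2. The step expected for compound 4 is a 7.5-fold higher number from compound 3 to compound 4 (0.88 log units; beyond the scatter); this rests on an at least 4.3-fold higher number from compound 1 to compound 2 (0.63 log units; beyond the scatter). For compound 4 an estimate of 6000 nM is made, from 2000 nM to 30000 nM.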

Compound 4, half-maximal inhibitory concentration: 1500 nM
Compound 4: the middle estimate sits 4.0-fold (0.60 log units) above what was measured, outside the stated range (below it).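

Formyl to acetyl on the second core gives a 1.9-fold higher number from compound 3 to compound 4 (0.27 log units; within the scatter) in this assay, so on this core the change cannot be told apart from repeat scatter. Set beside the earlier step, the comparison reads: the same change on two cores in this assay, an at least 4.3-fold higher number (0.63 log units; beyond the scatter) from compound 1 to compound 2 and a 1.9-fold higher number (0.27 log units; within the scatter) from compound 3 to compound 4; the limit leaves it open whether they differ. Compound 2 is a limit of the assay at > 100000 nM, so the size of the earlier step stays unfixed, and the series shows neither that the change carries over unaltered nor that its size depends on the core.

The compounds shown leave open how an ethyl group, a longer chain or an amine on the same carbonyl carbon would read on either core. They also leave open how formyl to acetyl reads on any further core.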